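The source may hold more compounds than are shown below. What is called first, only, known or untested is meant among the compounds shown, and "the series" means these compounds.

Measured in an ADME assay on microsomes from liver (Mus musculus) for metabolic stability, read by LC-MS, with a stated time of 10 min, tested at 0.5 uM; a lower number here means that less of the compound is left, a higher number that more of the compound is left:

- Compound 1 `c1ccc2c(c1)CN[C@@H](CN(CC[C@@H]1CCCNC1)[C@H]1CCCc3cccnc31)C2`: 23%
- Compound 2 `c1cnc2c(c1)CN[C@@H](CN(CCCN1CCNCC1)[C@H]1CCCc3cccnc31)C2`: 78%
- Compound 3 `c1cnc2c(c1)CCC[C@@H]2N(CCCN1CCNCC1)Cc1nc2ccccc2s1`: 45%

Of these three, compound 1 stands lowest at 23%, clearly under both compound 3 at 45% and compound 2 at 78%. Compound 4 `c1ccc2c(c1)CN[C@@H](CN(CC[C@H]1CCCNC1)[C@H]1CCCc3cccnc31)C2` is its direct partner: the two compounds have the same atoms and bonds and differ only in configuration as drawn: 1 of 3 stereo elements differ; a stereocentre at a saturated ring carbon is drawn S in compound 1 and R in compound 4. No atom or bond changes, only the way that one stereocentre at a saturated ring carbon is drawn.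

Among the measured compounds shown here, the only measured step between compounds that differ in one place is a number 33 percentage points lower from compound 2 to compound 3 (beyond the scatter). For the measured compounds named here, that large step replaces one group with another, so it says little about a change of configuration alone, and the data hold no measured pair of stereoisomers. The expectation therefore starts from compound 1 at 23%, with no direction favoured and no shift beyond the scatter, though the uncertainty is wide. The expected step is a number 3 percentage points higher from compound 1 to compound 4 (within the scatter). For compound 4 the estimated value is 26%, with an expected range from 12% to 45%.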

Compound 4, percent of the compound remaining: 56%
Compound 4: the middle estimate sits 30 percentage points below what was measured, outside the stated range (above it).
By their numbers in this assay, from the lowest: compound 1; then compound 3; then compound 4; then compound 2.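

In this assay, redrawing the stereocentre at a saturated ring carbon from S to R gives a number 33 percentage points higher from compound 1 to compound 4 (beyond the scatter). Among the compounds shown here, this is the first sign in these compounds that configuration at this position alone can matter as much in this read-out as replacing a whole group, which the earlier step of a number 33 percentage points lower from compound 2 to compound 3 (beyond the scatter) showed. The gain can be assigned to this one stereocentre, because no other structural change is present: the fact that compounds 1 and 4 differ only in the configuration as drawn

The pair does not show how the two remaining stereo elements affect the amount of compound left, or whether the R form keeps its advantage on other cores. Nor does it show whether that advantage would survive an acetyl group on the nitrogen of the saturated ring or a methyl group on that ring.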